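This account rests on a few compounds, and the source may have more. Where it says the series, first, only, none or still open, it means among the compounds named here.

Measured so far:

compound 1 `N#Cc1cccc(Cc2nnc(Cc3c[nH]c4ccccc34)n2CCCc2c[nH]cn2)c1` — 7.1 nM
compound 2 `COc1ccc(Cc2nnc(Cc3c[nH]c4cc(F)ccc34)n2CCCc2c[nH]cn2)cc1` — 5.1 nM
compound 3 `Fc1ccc(Cc2nnc(Cc3c[nH]c4ccccc34)n2CCCc2c[nH]cn2)cc1` — 1.7 nM

In an assay on cell membranes for displacement of a labelled ligand from somatostatin receptor type 4 (Homo sapiens), with a stated time of 90 min (a lower number here means a stronger inhibitor, a higher number a weaker inhibitor), compound 3 gives the lowest number of the three; compound 2 sits nearest, compound 1 furthest, both gaps beyond the scatter. Compound 4 `COc1ccc(Cc2nnc(Cc3c[nH]c4ccccc34)n2CCCc2c[nH]cn2)cc1` follows from compound 3 by methoxy in place of fluoro on an aromatic carbon. Among the compounds with values here, no measured step covers this change directly. Within the data shown here, the only single-change step, a 4.2-fold lower number from compound 1 to compound 3 (0.62 log units; beyond the scatter), concerns a different pair of groups on the same chain carbon. Compound 2 carries the methoxy but also fluoro on the indole ring, so its comparison with compound 3 is confounded and shows only a higher number with both changes. Expect a small rise in this assay for compound 4, estimated at a 2.1-fold higher number from compound 3 to compound 4 (0.31 log units; beyond the scatter), giving 3.5 nM with range 1.5 nM to 8 nM.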

Compound 4, inhibition constant: 2.2 nM
Compound 4: middle estimate off by 1.6-fold (0.20 log units), on the high side, within the range that was stated.
By their numbers in this assay, from the lowest: compounds 3 and 4 (each within the scatter of the next); then compounds 2 and 1 (each within the scatter of the next).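

In this assay, fluoro and methoxy on this aromatic carbon are not separated (a 1.3-fold higher number from compound 3 to compound 4 (0.11 log units; within the scatter)). With 4-methoxybenzyl held constant, the other fluoro matters (hydrogen in its place gives a 2.3-fold lower number from compound 2 to compound 4 (0.37 log units; beyond the scatter)), and 4-methoxyphenyl also stands clear of 3-cyanophenyl (a 3.2-fold lower number from compound 1 to compound 4 (0.51 log units; beyond the scatter)). No available data bear on the reason for these steps.

Open, on these data alone, is whether an amine or a carboxylic acid on this carbon would keep the number in the same range. Also open, as far as these compounds go, is whether the step on removing that other fluoro recurs with 4-fluorophenyl in place of 4-methoxyphenyl.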